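This account rests on a few compounds, and the source may have more. Where it says the series, first, only, none or still open, it means among the compounds named here.

In a functional assay on A2780 cells (Homo sapiens) for antiproliferative activity, read by sulforhodamine B assay, with a stated time of 72 h (a lower number here means a stronger inhibitor, a higher number a weaker inhibitor), compound 1 `N#C/N=C(\NCc1ccc(S(=O)(=O)c2ccccc2)cc1)Nc1cccnc1` gives 30 nM and compound 3 `N#C/N=C(\NCc1ccc(S(=O)(=O)N2CC3CCC(C2)O3)cc1)Nc1cccnc1` gives 175 nM. Compound 2 `COc1cccc(S(=O)(=O)c2ccc(CN/C(=N\C#N)Nc3ccncc3)cc2)c1` gives 3.4 nM, the lowest of the three numbers. Compound 4 `N#C/N=C(\NCc1ccc(S(=O)(=O)c2cccc(OC(F)(F)F)c2)cc1)Nc1ccncc1` has not yet been measured. Its difference from compound 2 is trifluoromethyl in place of methyl on an oxygen on an aromatic ring, or methoxy to trifluoromethoxy. Among the compounds with values here, only one measured step links two compounds that differ in one place, a 5.8-fold higher number from compound 1 to compound 3 (0.77 log units; beyond the scatter). That step exchanges the whole group on a sulfonyl sulfur and leaves no group on an aromatic oxygen changed, so it bears only weakly on this comparison. Within the data shown here, no measured pair shows what this exchange does, and the data give no firm direction for it. The expected change in this assay is therefore small and within the scatter, an estimated 1.5-fold higher number from compound 2 to compound 4 (0.17 log units; within the scatter). For compound 4 the estimated value is 5 nM, with an expected range of 1.5 nM to 16 nM.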

Compound 4, half-maximal inhibitory concentration: 2.2 nM
Compound 4: middle estimate off by 2.3-fold (0.36 log units), on the high side; the measured number falls inside the stated range.
By their numbers in this assay, from the lowest: compounds 4 and 2 (each within the scatter of the next); then compound 1; then compound 3.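

In this assay, within the data shown here, the one measured step at this place, trifluoromethyl in place of methyl on an oxygen on an aromatic ring, gives a 1.5-fold lower number from compound 2 to compound 4 (0.19 log units; within the scatter). This shows that the place accepts trifluoromethyl and that compound 2 and compound 4 cannot be told apart in this assay, so the methoxy to trifluoromethoxy exchange leaves the low numbers of this pair intact. Nothing available here offers a reason for this outcome.

The compounds shown leave open how a hydroxyl, an ethoxy or an amine would fare in place of methoxy on this ring. A single pair also leaves open whether the same exchange would give a similar result on a different core.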